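Hydroxy on the sulfonamide propyl chain: compound 1 to compound 4

The source may hold more compounds than are shown below. What is called first, only, known or untested is meant among the compounds shown, and "the series" means these compounds.

Measured in a functional assay on HeLa cells (Homo sapiens) for antiproliferative activity, read by CCK-8 assay, with a stated time of 72 h; on this read-out higher numbers stand for weaker inhibition of growth and lower numbers for stronger inhibition of growth:
- compound 1 `CCCNS(=O)(=O)c1ccc(Nc2ncc3c(n2)N(C2CCCC2)[C@H](CC)C(=O)N3C)cc1`: 459 nM
- compound 2 `CCC1C(=O)N(C)c2cnc(-n3ccc4cc(C(=O)NCC(C)C)ccc43)nc2N1c1ccn(C)n1`: 4970 nM
- compound 3 `CC[C@@H]1C(=O)N(C)c2cnc(-n3ccc4cc(C(=O)NC)ccc43)nc2N1C1CCCC1`: 768 nM

Compound 1 has the lowest number of the three. Compound 3 sits within the usual scatter of compound 1, so the two cannot be ordered against each other. Compound 2 stands clearly apart, with a number beyond the scatter above compound 1. Among the measured compounds shown here, no pair of these three differs in only one place, so no single step can be read from them.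

Compound 4 `CC[C@@H]1C(=O)N(C)c2cnc(Nc3ccc(S(=O)(=O)NCCCO)cc3)nc2N1C1CCCC1` is not yet measured. It differs from compound 1 by one change on the sulfonamide side chain: hydroxy in place of hydrogen on a saturated chain carbon, three bonds along the chain from a sulfonamide nitrogen. The shared core and its substituents are otherwise unchanged, and the chain keeps its length.

For the measured compounds named here, with nothing among the measured compounds bearing on this change, the expectation is a step of a 1.1-fold higher number from compound 1 to compound 4 (0.04 log units; within the scatter) in this assay, that is, no move beyond the scatter in either direction. Compound 4 is therefore estimated at 500 nM, with a range from 200 nM to 1300 nM.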

Compound 4, concentration for 50% growth inhibition: 357 nM
For compound 4 the middle estimate is 1.4-fold (0.15 log units) above the measured one; the measured number falls inside the stated range.
By their numbers in this assay, from the lowest: compounds 4, 1 and 3 (each within the scatter of the next, the first and the last beyond it); then compound 2.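

In this assay the change from propyl to 3-hydroxypropyl gives a 1.3-fold lower number from compound 1 to compound 4 (0.11 log units; within the scatter) and this step lies within the scatter, so the two compounds cannot be ordered against each other. It is the only single-place comparison among the compounds shown, and it indicates that hydroxy in place of hydrogen is tolerated on this saturated chain carbon, three bonds along the chain from a sulfonamide nitrogen, with no move beyond the scatter in either direction. Nothing available gives a reason for this outcome.

Still open, on these data alone, is whether an amine, a carboxylic acid or a methoxy group at this same carbon would also stay within the scatter. A longer chain ending in hydroxy also remains untested by the compounds shown here.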